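Removing Trifluoromethyl From an Allyl-Bearing Biaryl Phenol

This account rests on a few compounds, and the source may have more. Where it says the series, first, only, none or still open, it means among the compounds named here.

Measured compounds:
compound 1, `C=CCc1cc(-c2ccc(C(F)(F)F)cc2)ccc1OC`, > 100000 nM;
compound 2, `C=CCc1ccc(OCC(=O)OCC)c(-c2ccc(OCC(=O)OCC)c(CC=C)c2)c1`, > 100000 nM;
compound 3, `C=CCc1cc(-c2cccc(C(F)(F)F)c2)ccc1O`, 76000 nM.

In a functional assay on HUVEC cells (Homo sapiens) for antiproliferative activity, read by MTT assay, with a stated time of 24 h (a higher number here means a weaker inhibitor, a lower number a stronger inhibitor), compound 1 reaches only a limit of the assay. Compound 2 likewise gives only a limit in this assay. For the measured compounds named here, compound 3 is the one compound with an actual number in this assay, standing alone against two limits, as summed up in the limit of > 100000 nM in this assay, at which 2 of the 3 values shown sit.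

Compound 4 is `C=CCc1cc(-c2ccccc2)ccc1O`. It differs from compound 3 by hydrogen in place of trifluoromethyl on an aromatic carbon. Going by the values given here, no pair of measured compounds separates this change. The step can therefore only be expected, not inferred. The expected step in this assay is a 2.0-fold higher number from compound 3 to compound 4 (0.30 log units; within the scatter), a small shift toward weaker inhibition, and compound 4 is estimated at 150000 nM in this assay, between 50000 nM and 500000 nM.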

Compound 4, half-maximal inhibitory concentration: > 100000 nM
Compound 4 was reported as a limit (the forecaster's own chance of this, stated with the estimate: 60%); the middle value lies beyond the limit too.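

In this assay compound 4 gives only a limit, > 100000 nM. Replacing trifluoromethyl with hydrogen on this aromatic carbon gives an at least 1.3-fold higher number from compound 3 to compound 4 (0.11 log units; that floor lies within the scatter), which is a floor on the change and not its size. Compound 3 thus remains the only compound with an actual number: the limit of > 100000 nM in this assay, at which 3 of the 4 values shown sit.

From the compounds shown here alone, how far compound 4 lies beyond its limit stays open, so the full size of this change cannot be read. Also open, going by these compounds, is whether a nitrile, an amine or a carboxylic acid on this same aromatic carbon would give an actual number in this assay.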